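The compounds below may be only part of what the source reports. "The series", "measured", "known", "first", "only" and "open" are said of these compounds alone.

Working notes on the series. In a functional assay on KYSE-450 cells (Homo sapiens) for inhibition, read by CCK-8 assay, with a stated time of 48 h (on this read-out lower numbers stand for stronger inhibition and higher numbers for weaker inhibition), compound 1 `COc1ccc(CN(C(=O)CSC(=S)N2CCc3cc(OC)ccc32)c2cc(OC)c(OC)c(OC)c2)cc1` gives 10200 nM, compound 2 `COc1cc(N(Cc2ccc(Cl)cc2)C(=O)CSC(=S)N2CCN(C(=O)OC(C)(C)C)CC2)cc(OC)c1OC` gives 11900 nM and compound 3 `COc1cc(N(Cc2ccc(Br)cc2)C(=O)CSC(=S)N2CCN(C(=O)OC(C)(C)C)CC2)cc(OC)c1OC` gives 10700 nM. These three values lie within the scatter of one another, so compound 3 holds no distinct rank among them.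

Compound 4 `COc1ccc(CN(C(=O)CSC(=S)N2CCN(C(=O)OC(C)(C)C)CC2)c2cc(OC)c(OC)c(OC)c2)cc1OC` keeps the rest of compound 3 and alters one group: 3,4-dimethoxyphenyl in place of 4-bromophenyl on a saturated chain carbon bound to an amide-type nitrogen. Within the data shown here, only one measured step bears on this group, namely a 1.1-fold lower number from compound 2 to compound 3 (0.05 log units; within the scatter). That step, bromo in place of chloro on an aromatic carbon, stays within the scatter, but it is a much smaller structural change than the one at hand. Among the measured compounds shown here, no measurement yet tests the 3,4-dimethoxybenzyl group on this core.

No step beyond the scatter is therefore expected in this assay, and confidence in that is modest. The estimated step is a 1.1-fold lower number from compound 3 to compound 4 (0.03 log units; within the scatter). Compound 4 is expected at 10000 nM, with an estimated range of 4500 nM to 22000 nM.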

Compound 4, half-maximal inhibitory concentration: > 20000 nM
Compound 4 ended at the assay's limit; the forecaster's own chance of this, stated with the estimate: 10%; at least 2.0-fold (0.30 log units) between middle value and limit.
By their numbers in this assay, from the lowest: compounds 1, 3 and 2 (each within the scatter of the next). At a limit, above all of these: compound 4.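

At this position, on a saturated chain carbon bound to an amide-type nitrogen, 3,4-dimethoxyphenyl in place of 4-bromophenyl gives an at least 1.8-fold higher number from compound 3 to compound 4 (0.27 log units; that floor lies within the scatter), and in place of 4-chlorophenyl it gives an at least 1.6-fold higher number from compound 2 to compound 4 (0.22 log units; that floor lies within the scatter). In this assay, compound 4 stands at a limit of the assay and not at a number: the limit of > 20000 nM in this assay, at which 1 of the 4 values shown sits. Among these compounds, the bromo for chloro exchange, a 1.1-fold lower number from compound 2 to compound 3 (0.05 log units; within the scatter), left the read-out measurable, whereas this larger change is the first here to reach the limit, although neither floor lies beyond the scatter, so a real loss at this position is suggested but not established.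

The compounds shown leave open how far past its limit compound 4 lies, and whether the result follows from the methoxy groups or from the loss of the halogen. A 4-methoxyphenyl or a 4-aminophenyl group at this position on the core of compound 3 would separate these readings.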